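This account rests on a few compounds, and the source may have more. Where it says the series, first, only, none or still open, it means among the compounds named here.

Working notes on the series. The shared core carries two arylidene groups and an N-substituent that varies across the set. Compound 1 `COc1ccccc1/C=c1/[nH]c(=O)/c(=C\c2ccccc2OC)n(C)c1=O` bears two methoxyphenyl arms and a methyl on the ring nitrogen; in a functional assay on A549 cells (Homo sapiens) for cytotoxicity, read by CCK-8 assay, with a stated time of 72 h (on this read-out lower numbers stand for stronger inhibition and higher numbers for weaker inhibition), compound 1 gives 7000 nM. Compound 2 `COc1ccccc1/C=c1/[nH]c(=O)/c(=C\c2cccc(Cl)c2Cl)[nH]c1=O` replaces one arm with a dichlorophenyl group and carries no substituent on either ring nitrogen; in this assay compound 2 is reported as "not active" (no number reported), with no number attached. Compound 3 `C=CCn1c(=O)/c(=C\c2cccc(Cl)c2Cl)[nH]c(=O)/c1=C\c1ccccc1OC` keeps the dichlorophenyl arm and adds an allyl on the ring nitrogen; in this assay compound 3 gives 2300 nM, the lowest of the two numbers at hand, with compound 1 standing at a higher value, a gap beyond the usual scatter.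

Compound 4 `COc1ccccc1/C=c1\c(=O)[nH]/c(=C/c2cccc(Cl)c2Cl)c(=O)n1C` is the next entry, not yet measured in this assay. Relative to compound 3 the change is hydrogen in place of vinyl on a saturated chain carbon bound to an aromatic nitrogen. For the measured compounds named here, no pair of measured compounds differs by this change alone, so the size of the step can only be judged from the surroundings: the methyl-bearing compound 1 sits at 7000 nM, while the unsubstituted compound 2 is reported inactive. On that basis a small step, weakening if anything and close to the scatter, is expected from compound 3 to compound 4, a 1.7-fold higher number from compound 3 to compound 4 (0.24 log units; within the scatter). For compound 4 the expected value in this assay is 4000 nM, with a range from 1500 nM to 12000 nM.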

Compound 4, half-maximal inhibitory concentration: 200 nM
Estimate against measurement, compound 4: 20-fold (1.30 log units) above; measured number outside the range, below it.
By their numbers in this assay, from the lowest: compound 4; then compound 3; then compound 1.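

In this assay, for the compounds shown here, the chain on the aromatic nitrogen proves far more consequential than the earlier compounds could show: going from allyl to methyl gives a 12-fold lower number from compound 3 to compound 4 (1.06 log units; beyond the scatter) with the rest of the structure unchanged, so losing the vinyl alone produces a large step at this position. Going by these compounds alone, with the methyl held in place, 2,3-dichlorophenyl in place of 2-methoxyphenyl on the double-bonded chain carbon gives a 35-fold lower number from compound 1 to compound 4 (1.54 log units; beyond the scatter) and shows that the arm also carries a large step, one that no earlier pair could isolate. No measured information on the series accounts for either step.

Steps to compound 2 cannot be read, as it has no number, so the effect of a bare hydrogen on the aromatic nitrogen stays unquantified, and it remains unclear whether an ethyl, a propyl or an aminoethyl chain there would fall nearer to methyl or to allyl. Also open, from the compounds shown here alone, is whether the gain from the 2,3-dichlorophenyl arm holds with allyl on the nitrogen, or with a single chlorine on the phenyl ring.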